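The source may hold more compounds than are shown below. What is called first, only, known or untested is meant among the compounds shown, and "the series" means these compounds.

In a functional assay on HCT-116 cells (Homo sapiens) for antiproliferative activity, read by CCK-8 assay, with a stated time of 72 h (a lower number here means a stronger inhibitor, a higher number a weaker inhibitor), compound 1 (`Nc1ccccc1NC(=O)c1ccc(CSc2cccc(F)c2)cc1`) gives 2870 nM. Going by the values given here, compound 2 (`Cc1ccc(SCc2ccc(C(=O)Nc3ccccc3N)cc2)cc1`) gives 2630 nM, which lies within the scatter of the value for compound 1, so compound 2 stands level with the only other measured member of the series.

The next compound is compound 3 (`Nc1ccccc1NC(=O)c1ccc(CSCCc2ccccc2)cc1`), with phenethyl in place of 4-methylphenyl on a sulfur.

Among the compounds with values here, only one measured step bears on this change: a 1.1-fold lower number from compound 1 to compound 2 (0.04 log units; within the scatter), for 4-methylphenyl in place of 3-fluorophenyl on a sulfur. That step is small and within the scatter, but it is only weak guidance, as it exchanges one substituted phenyl group for another. Within the data shown here, no measured compound carries phenethyl, so the data hold no direct precedent for this group.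

No step beyond the scatter is therefore expected in this assay, and no direction is favoured. The expected change is a 1.1-fold higher number from compound 2 to compound 3 (0.03 log units; within the scatter). For compound 3 the estimated value is 2800 nM, with an expected range of 1000 nM to 8000 nM, kept wide for the lack of precedent.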

Compound 3, half-maximal inhibitory concentration: 2810 nM
Estimate against measurement, compound 3: 1.0-fold (0.00 log units) below; low and high end bracket the measured number.
By their numbers in this assay, from the lowest: compounds 2, 3 and 1 (each within the scatter of the next).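

Going by these compounds alone, compound 3 is the first member in which the sulfur carries no substituted phenyl group, and in this assay the exchange of 4-methylphenyl for phenethyl leaves the number level (a 1.1-fold higher number from compound 2 to compound 3 (0.03 log units; within the scatter)). The exchange of 3-fluorophenyl for phenethyl reads the same way (a 1.0-fold lower number from compound 1 to compound 3 (0.01 log units; within the scatter)), so across these three compounds this position on the sulfur, whose other neighbour is a saturated chain carbon, accepts both directly attached substituted phenyl groups and phenethyl without a step beyond the scatter. No supporting measurement is available to explain why the values stay level.

As far as these compounds go, all three groups are carbon-only and each contains one six-membered aromatic ring, so it remains open whether a longer chain, an amine or a carboxylic acid at this position would also stay within the scatter. From the compounds shown here alone, it is equally open whether the sulfur itself can give way to an oxygen atom or a sulfonyl group, and whether any change to the rest of the shared core would move the number further than these exchanges have.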